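Swapping the aryl end of the chain for thiophene

The source may hold more compounds than are shown below. What is called first, only, known or untested is meant among the compounds shown, and "the series" means these compounds.

Compound 1 `O=c1[nH]/c(=N\OCCCCc2ccccc2)ccn1[C@@H]1O[C@H](COP(=O)(O)OP(=O)(O)OP(=O)(O)O)[C@@H](O)[C@H]1O` gives 54 nM in a functional assay on 1321-N1 cells for agonist activity at P2Y purinoceptor 4 (Homo sapiens), read by scintillation counting and inositol phosphate accumulation; on this read-out lower numbers stand for an effect already at smaller amounts and higher numbers for an effect only at larger amounts of compound.
Compound 2 `O=c1[nH]/c(=N\OCCCc2ccc(I)cc2)ccn1[C@@H]1O[C@H](COP(=O)(O)OP(=O)(O)OP(=O)(O)O)[C@@H](O)[C@H]1O` gives 91 nM in this assay.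
Compound 3 `COc1ccc(CCCO/N=c2/ccn([C@@H]3O[C@H](COP(=O)(O)OP(=O)(O)OP(=O)(O)O)[C@@H](O)[C@H]3O)c(=O)[nH]2)cc1` gives 23 nM in this assay.

Compound 3 has the lowest number of the three. Compound 1 differs from it only at the end of the chain, and the step of a 2.3-fold lower number from compound 1 to compound 3 (0.37 log units; beyond the scatter) is beyond the scatter. Compound 2 carries an iodo group where compound 3 carries methoxy, and the step of a 4.0-fold lower number from compound 2 to compound 3 (0.60 log units; beyond the scatter) is larger still. The step of a 1.7-fold higher number from compound 1 to compound 2 (0.23 log units; within the scatter) lies within the scatter.

Compound 4 `O=c1[nH]/c(=N\OCCCc2ccsc2)ccn1[C@@H]1O[C@H](COP(=O)(O)OP(=O)(O)OP(=O)(O)O)[C@@H](O)[C@H]1O` has not been measured. It differs from compound 3 in one place: thiophen-3-yl in place of 4-methoxyphenyl on a saturated chain carbon, three bonds along the chain from an oxygen on an unsaturated carbon. Among the compounds with values here, two measured steps bear on this. The methoxy group that helped compound 3 is gone in compound 4, and removing it gave the step from compound 1 to compound 3 in reverse, a modest rise. Nothing measured here says what replacing the six-membered ring by a five-membered one does, so that part is open. A modest rise is therefore expected, a 2.2-fold higher number from compound 3 to compound 4 (0.34 log units; beyond the scatter).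

Compound 4 is expected to give about 50 nM, within a range from 20 nM to 130 nM.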

Compound 4, half-maximal effective concentration: 20 nM
Beside the measured number, compound 4's estimate is 2.5-fold (0.40 log units) above it; low and high end bracket the measured number.
By their numbers in this assay, from the lowest: compounds 4 and 3 (each within the scatter of the next); then compounds 1 and 2 (each within the scatter of the next).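

At the end of the propyl chain, thiophen-3-yl, with 5 heavy atoms and a five-membered ring, stands level with the 8 heavy atoms of 4-methoxyphenyl: this assay shows a 1.2-fold lower number from compound 3 to compound 4 (0.06 log units; within the scatter) as the change, so a low number here does not require a methoxy group or a six-membered ring. The thiophene compound also stays clear of the two remaining compounds, with a 4.6-fold lower number from compound 2 to compound 4 (0.66 log units; beyond the scatter) and a 2.7-fold lower number from compound 1 to compound 4 (0.43 log units; beyond the scatter) as its steps, which places compound 3 and compound 4 together, apart from compound 1 and compound 2, though compound 1 also differs in its chain. No measurement offered here accounts for why these two different ring ends give such similar numbers.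

The compounds shown leave open whether the sulfur atom matters at all, a question that an unsubstituted phenyl or a furan-3-yl ring on the same propyl chain could address. They also leave open how far the result depends on the ring's attachment point and chain length, which thiophen-2-yl on the propyl chain and thiophen-3-yl on a longer chain could test.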